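This account rests on a few compounds, and the source may have more. Where it says the series, first, only, none or still open, it means among the compounds named here.

Compound 2 `O=C(O)CC[C@H]1CCc2cc(-c3cc(OC4CCC4)cc(F)c3F)ccc2O1` was tested in a functional assay on HEK293 cells for agonist activity at Free fatty acid receptor 1 (Homo sapiens), read by HTRF and inositol phosphate accumulation, with a stated time of 60 min; on this read-out higher numbers stand for an effect only at larger amounts of compound and lower numbers for an effect already at smaller amounts. In this assay compound 2 reaches only > 10000 nM, which is a limit of the assay and not a number, and it sits at the limit of > 10000 nM in this assay, at which 1 of the 2 values shown sits. Compound 1 `O=C(O)CC[C@H]1CCc2cc(-c3cc(OC(F)(F)F)cc(Cl)c3F)ccc2O1` carries a trifluoromethoxy group and a chloro group in its outer ring, and in this assay compound 1 gives 2200 nM. Among the compounds with values here, no single step links compound 1 and compound 2, as they differ in two places, so their two values show only where each of them stands. Compound 3 `O=C(O)CC[C@H]1CCc2cc(-c3cc(OC4CCC4)cc(Cl)c3F)ccc2O1` has not yet been measured. It differs from compound 2 by chloro in place of fluoro on an aromatic carbon. No step of this exact kind has been measured among these compounds. Because compound 1 gives 2200 nM in this assay while bearing the same chloro group, the step is expected to run toward lower values, by about an at least 2.0-fold lower number from compound 2 to compound 3 (0.30 log units; that floor lies within the scatter). The estimate for compound 3 in this assay is 5000 nM, with a range from 1500 nM to 20000 nM.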

Compound 3, half-maximal effective concentration: > 10000 nM
Compound 3 gave a limit, no number; the forecaster's own chance of this, stated with the estimate: 40%; at least 2.0-fold (0.30 log units) between middle value and limit.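

In this assay the change from fluoro to chloro cannot be read, because compound 2 and compound 3 both stand at a limit of the assay and not at a number: the limit of > 10000 nM in this assay, at which 2 of the 3 values shown sit.

Compound 3 gives > 10000 nM, which is a limit and not a number, so chloro at this place, ortho to a fluoro group and with the cyclobutyloxy group kept, yields no readable value. Within the data shown here, what the earlier compounds did not show is that the chloro group alone does not bring a readable value: with chloro held in place, cyclobutyl in place of trifluoromethyl on an oxygen on an aromatic ring is an at least 4.5-fold higher number from compound 1 to compound 3 (0.65 log units; beyond the scatter), and this single change on the oxygen is what separates the two.

The compounds shown leave open whether chloro and fluoro differ at this place when the oxygen carries trifluoromethyl, where a number can be read. They also leave open how a methyl or a cyclopropyl group on that oxygen, or a nitrile in place of the chloro group, would stand in this assay.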